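Side-chain change from compound 2 to compound 3

The source may hold more compounds than are shown below. What is called first, only, known or untested is meant among the compounds shown, and "the series" means these compounds.

- compound 1 `CCC(O)CO[C@H](CC=C(C)C)C1=CC(=O)c2c(O)ccc(O)c2C1=O`: 28700 nM
- compound 2 `CCCC(C)(O)CC(=O)O[C@H](CC=C(C)C)C1=CC(=O)c2c(O)ccc(O)c2C1=O`: 72000 nM
- compound 3 `CC(C)=CC[C@@H](OC(=O)C1CCCCO1)C1=CC(=O)c2c(O)ccc(O)c2C1=O`: not yet measured

Among the measured compounds shown here, in a functional assay on HeLa cells (Homo sapiens) for cytotoxicity, read by MTT assay (on this read-out lower numbers stand for stronger inhibition and higher numbers for weaker inhibition), compound 2 gives 72000 nM, the higher of the two numbers so far. Compound 3 keeps the shared core and the carbonyl group. The difference is oxan-2-yl in place of 2-hydroxy-2-methylpentyl on a carbonyl carbon, with oxan-2-yl in place of 2-hydroxy-2-methylpentyl on a carbonyl carbon.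

For the measured compounds named here, only one measured step bears on this: a 2.5-fold higher number from compound 1 to compound 2 (0.40 log units; beyond the scatter). It is a modest step, and it also falls on the side chain, with (2-hydroxy-2-methylpentyl)carbonyl in place of 2-hydroxybutyl on an oxygen on a saturated carbon. Going by the values given here, no measured compound carries oxan-2-yl, so the data do not fix the direction of the new step. With two values as the whole basis, a step of similar modest size is the working expectation, leaning towards the lower number of compound 1 at 28700 nM in this assay. The expected change is a 1.7-fold lower number from compound 2 to compound 3 (0.23 log units; within the scatter). Compound 3 is estimated at 42000 nM, with an expected range of 16000 nM to 100000 nM.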

Compound 3, half-maximal inhibitory concentration: > 100000 nM
Compound 3: no number, only a limit; the forecaster's own chance of this, stated with the estimate: 10%; at least 2.3-fold (0.37 log units) between middle value and limit.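

In this assay compound 3 gives no number, only a limit: the limit of > 100000 nM in this assay, at which 1 of the 3 values shown sits.

As far as these compounds go, replacing the open 2-hydroxy-2-methylpentyl, which has a hydrogen-bond donor, with the oxan-2-yl ring, which has none, on a carbonyl carbon gives an at least 1.3-fold higher number from compound 2 to compound 3 (0.14 log units; that floor lies within the scatter), so this step alone sets no order between the two side chains and its true size stays unknown. The firmer reading is an at least 3.4-fold higher number from compound 1 to compound 3 (0.54 log units; beyond the scatter), with (oxan-2-yl)carbonyl in place of 2-hydroxybutyl on an oxygen on a saturated carbon, so a second carbonyl-linked side chain, this time a ring, also reads on the weaker side of the 2-hydroxybutyl side chain.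

Still open, from the compounds shown here alone, are how far compound 3 lies beyond its limit and whether the ring or the absent hydroxyl carries the step. A plain pentyl chain on the carbonyl carbon, or a piperidin-2-yl ring with an amine nitrogen in place of the ring oxygen, would help separate these two readings.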